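A few compounds are considered here, and "the series" means these few. Any claim that something is new, unique, unknown or untested is made for them only; others in the source may bear on it.

Compound 1 `O=C1CCC(N2C(=O)c3ccc(Nc4ccccn4)cc3C2=O)C(=O)N1` is the reference point here. In an assay on FRT-Jurkat cells for inhibition of nuclear factor NF-kappa-B complex (Homo sapiens), read by flow cytometry, with a stated time of 24 h, tested at 10 uM (a higher number here means more inhibition at the concentration tested (going by the name of the read-out), a lower number less inhibition), compound 1 gives 9%, level with compound 2 `Cc1ccc(Nc2cccc3c2C(=O)N(C2CCC(=O)NC2=O)C3=O)cc1`, which in this assay gives 9%; together the two stand lowest among the three measured numbers. For the measured compounds named here, compound 3 `CC(C)(C)c1ccc(Nc2cccc3c2C(=O)N(C2CCC(=O)NC2=O)C3=O)cc1`, in which tert-butyl stands in place of methyl on an aromatic carbon, gives 36%, and the one measured step, a number 27 percentage points higher from compound 2 to compound 3 (beyond the scatter), is the only change beyond the scatter in the set.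

Compound 4 `Cc1ccccc1Nc1ccc2c(c1)C(=O)N(C1CCC(=O)NC1=O)C2=O` differs from compound 1 in the group on the amine nitrogen: 2-methylphenyl in place of pyridin-2-yl on a nitrogen on an aromatic ring. Going by the values given here, no measured step matches this change. The step from compound 2 to compound 3 concerns a different group on a different aromatic ring, so it bears on it only loosely, showing that a change on the aryl amine can move the number modestly. With compound 1 and compound 2 both low, the expected step of a number 4 percentage points higher from compound 1 to compound 4 (within the scatter) is small and within the scatter. Compound 4 is therefore estimated at 13%, in a range from 0% to 35%.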

Compound 4, a percentage reported as inhibition, at one concentration (the size of the read-out at that concentration, not a potency): 2%
Compound 4: middle estimate off by 11 percentage points, on the high side; measured number inside the range.
By their numbers in this assay, from the lowest: compounds 4, 1 and 2 (each within the scatter of the next); then compound 3.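

In this assay, 2-methylphenyl in place of pyridin-2-yl on the amine nitrogen gives a number 7 percentage points lower from compound 1 to compound 4 (within the scatter), so this exchange of an all-carbon ring for a ring holding one nitrogen does not separate the two compounds. For the compounds shown here, at this position, then, neither aryl group gives compound 1 or compound 4 a number that can be told apart from the other, while the only step beyond the scatter remains a number 27 percentage points higher from compound 2 to compound 3 (beyond the scatter), which belongs to a different pair and a different change. No measurement shown here accounts for the result.

On these data alone, it remains open whether a tert-butyl group on the phenyl ring of compound 4 would raise the number as it does in compound 3. Also open, as far as these compounds go, is how this position would respond to a non-aromatic group such as piperidine, or to a phenyl ring carrying a carboxylic acid.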